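The source may hold more compounds than are shown below. What is called first, only, known or untested is meant among the compounds shown, and "the series" means these compounds.

Working notes on the series.

Compound 1 `Nc1nn(C(=O)Nc2ccc(Cc3ccccc3)cc2)c2ccccc12` and compound 2 `Nc1nn(C(=O)Nc2ccc(Cc3ccccc3)cc2)c2ccc(Cl)cc12` share the urea-linked core; compound 2 carries a chloro on an aromatic carbon where compound 1 carries hydrogen. In a functional assay on HCT-15 cells (Homo sapiens) for antiproliferative activity, read by sulforhodamine B assay, with a stated time of 48 h (a lower number here means that less compound is tolerated, a higher number that more compound is tolerated), compound 1 gives > 100000 nM, which is a limit of the assay and not a number. In this assay compound 2 likewise gives > 100000 nM, again a limit rather than a number. The step from compound 1 to compound 2 in this assay, a step that the two limits leave unreadable from compound 1 to compound 2, therefore cannot be read in size or direction; both values sit at the limit of > 100000 nM in this assay, at which 2 of the 2 values shown sit.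

Compound 3 `Nc1ccc2c(c1)c(N)nn2C(=O)Nc1ccc(Cc2ccccc2)cc1` is the next member. It differs from compound 2 by amino in place of chloro on an aromatic carbon. Going by the values given here, the only measured step, the one from compound 1 to compound 2, is unreadable, so no measured step bears on the change from chloro to amino at this position, and no direction can be derived from the data.

Given that compound 2 sits at the limit in this assay, compound 3 is expected to remain near that limit, with an estimated step from compound 2 of a step that the limit leaves unreadable from compound 2 to compound 3. The estimate for compound 3 in this assay is 150000 nM, with a range from 40000 nM to 600000 nM.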

Compound 3, concentration lethal to 50% of the cells: 50500 nM
Estimate against measurement, compound 3: 3.0-fold (0.47 log units) above, and the stated range covers the measured number.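

Going by these compounds alone, at this aromatic carbon, meta to a fused ring and para to a fused ring, amino gives the first reading of the series that is a number and not a limit: in this assay compound 3 gives 50500 nM. Amino in place of chloro gives an at least 1.9-fold lower number from compound 2 to compound 3 (0.29 log units; that floor lies within the scatter), and amino in place of hydrogen gives an at least 1.9-fold lower number from compound 1 to compound 3 (0.29 log units; that floor lies within the scatter), so the two steps have the same direction, though each is known only by a floor and neither floor lies beyond the scatter. Chloro in place of hydrogen at this carbon gave no readable step, and compound 3 is the only member that departs from the shared limit: the limit of > 100000 nM in this assay, at which 2 of the 3 values shown sit.

As far as these compounds go, whether the number of compound 3 is specific to amino remains open, as does whether a hydroxyl, a methoxy or an acetamide at this carbon would also give a number rather than a limit. From the compounds shown here alone, the true size of both steps also remains open, since compound 1 and compound 2 each supply only a limit as the starting point.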